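The compounds below may be only part of what the source reports. "The series", "measured", "known", "first", "only" and "open" are said of these compounds alone.

Compound 1 `Cc1cn([C@@H]2O[C@H](CO[Si](C)(C)C(C)(C)C)[C@@]3(OS(=O)(=O)C=C3NCC(=O)O)[C@H]2O[Si](C)(C)C(C)(C)C)c(=O)n(C)c1=O` is the reference point of this small series. For the measured compounds named here, in a functional assay on CCRF-CEM cells (Homo sapiens) (on this read-out higher numbers stand for lower toxicity in this test and lower numbers for higher toxicity in this test), compound 1 gives 65000 nM, the highest of the three numbers measured so far, so on this read-out it is the least toxic of the measured compounds. Compound 2 `Cc1cn([C@@H]2O[C@H](CO[Si](C)(C)C(C)(C)C)[C@@]3(OS(=O)(=O)C=C3NCC(N)=O)[C@H]2O[Si](C)(C)C(C)(C)C)c(=O)n(C)c1=O` gives 14600 nM, and compound 3 `CC(=O)NC1=CS(=O)(=O)O[C@@]12[C@@H](CO[Si](C)(C)C(C)(C)C)O[C@@H](n1cc(C)c(=O)n(C)c1=O)[C@@H]2O[Si](C)(C)C(C)(C)C` gives 25700 nM. Both changes made from compound 1 so far lowered the number: a 4.5-fold lower number from compound 1 to compound 2 (0.65 log units; beyond the scatter), and a 2.5-fold lower number from compound 1 to compound 3 (0.40 log units; beyond the scatter). Between the two altered compounds the difference is small, a 1.8-fold higher number from compound 2 to compound 3 (0.25 log units; within the scatter).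

Compound 4 `Cc1cn([C@@H]2O[C@H](CO[Si](C)(C)C(C)(C)C)[C@@]3(OS(=O)(=O)C=C3NC(N)=O)[C@H]2O[Si](C)(C)C(C)(C)C)c(=O)n(C)c1=O` has not yet been measured. It differs from compound 1 by carbamoyl in place of carboxymethyl on an amine nitrogen. As in compound 2 and compound 3, the carboxymethyl group of compound 1 is no longer present in its original form, so the two measured steps from compound 1 are the ones that bear on this change. Each of them was modest and pointed in the same direction, toward a lower number, and nothing in the measured data points the other way.

A modest step downward is therefore expected a 3.0-fold lower number from compound 1 to compound 4 (0.47 log units; beyond the scatter), because a 4.5-fold lower number from compound 1 to compound 2 (0.65 log units; beyond the scatter) and a 2.5-fold lower number from compound 1 to compound 3 (0.40 log units; beyond the scatter) both went that way. Compound 4 is thus expected to give about 22000 nM, with a likely range from 9000 nM to 50000 nM.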

Compound 4, half-maximal cytotoxic concentration: 4360 nM
Beside the measured number, compound 4's estimate is 5.0-fold (0.70 log units) above it, and the stated range ends above it.
By their numbers in this assay, from the lowest: compound 4; then compounds 2 and 3 (each within the scatter of the next); then compound 1.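

On the amine nitrogen, the change from (carboxymethyl)amino to ureido produces the largest move seen so far in this assay (a 15-fold lower number from compound 1 to compound 4 (1.17 log units; beyond the scatter)), and here a lower number means higher toxicity. Compound 4 also stands apart from the two compounds that had looked alike, since amino in place of methyl on the carbonyl carbon gives a clear drop (a 5.9-fold lower number from compound 3 to compound 4 (0.77 log units; beyond the scatter)), as does carbamoyl in place of carbamoylmethyl (a 3.3-fold lower number from compound 2 to compound 4 (0.52 log units; beyond the scatter)), so compound 4 has the lowest number of the four and small edits at this position can matter more than compounds 2 and 3 suggested. No measurement shown here explains why the ureido compound stands lowest.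

From the compounds shown here alone, it remains open whether a methyl group on the outer nitrogen of the ureido group, a sulfonamide on the amine nitrogen, or a longer chain such as carbamoylethyl would lower the number further or raise it again. Going by these compounds, with only this one read-out, it also remains open whether the same order would hold in other cell types.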